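Swapping dimethylamino for vinyl in compound 3

The source may report more compounds than this note shows. Statements on the series, on what has been measured and on what is new or still open speak of the compounds shown alone.

Measured in a functional assay on MCF7 cells (Homo sapiens) for inhibition, read by CCK-8 assay, with a stated time of 48 h; a lower number here means a stronger inhibitor, a higher number a weaker inhibitor:
compound 1 `COc1cc(-c2ccnc3cc(-c4ccccc4)nn23)cc(OC)c1OC` gives 254 nM
compound 2 `COc1cc(-c2ccnc3cc(-c4ccc(N(C)C)cc4)nn23)cc(OC)c1OC` gives 44 nM

Of these two, compound 2 stands lowest in this assay and is the stronger inhibitor. Still unmeasured is compound 3 `C=Cc1ccc(-c2cc3nccc(-c4cc(OC)c(OC)c(OC)c4)n3n2)cc1`, which differs from compound 2 by this change: vinyl in place of dimethylamino on an aromatic carbon. In plain terms, vinyl takes the place of dimethylamino on an aromatic carbon, para to a large group. For the measured compounds named here, only one measured step bears on this, and it is a modest one: a 5.8-fold lower number from compound 1 to compound 2 (0.76 log units; beyond the scatter), with dimethylamino in place of hydrogen on an aromatic carbon. Compound 3 gives up that dimethylamino, so a move back towards compound 1 is expected. Going by the values given here, no measured compound carries vinyl, however, so the size of that move rests on this single step, and a full return is not assumed. The expected change is a 2.7-fold higher number from compound 2 to compound 3 (0.44 log units; beyond the scatter), which would be a somewhat smaller move than the measured one, towards a higher number. For compound 3 the estimated value is 120 nM, with an expected range from 45 nM to 320 nM.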

Compound 3, half-maximal inhibitory concentration: 193 nM
The estimate for compound 3 lay 1.6-fold (0.21 log units) below the measured number, and the stated range covers the measured number.
By their numbers in this assay, from the lowest: compound 2; then compounds 3 and 1 (each within the scatter of the next).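

In this assay, vinyl in place of dimethylamino on this aromatic carbon gives a 4.4-fold higher number from compound 2 to compound 3 (0.64 log units; beyond the scatter), so the gain seen with dimethylamino does not carry over to vinyl, a group of similar size by heavy-atom count that has no nitrogen. Vinyl in place of hydrogen gives a 1.3-fold lower number from compound 1 to compound 3 (0.12 log units; within the scatter), which leaves vinyl and hydrogen indistinguishable at this position, and among these three compounds only the dimethylamino group of compound 2 stands apart from the others. No available evidence accounts for the difference between dimethylamino and vinyl.

With only three groups compared at this one position, the compounds shown leave open whether the gain is particular to dimethylamino or extends to other amines, such as a primary amine, diethylamino or morpholine. They also leave open whether an oxygen-linked group such as methoxy, or a saturated chain such as ethyl, would match hydrogen and vinyl or come closer to dimethylamino.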